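A few compounds are considered here, and "the series" means these few. Any claim that something is new, unique, unknown or untested is made for them only; others in the source may bear on it.

Values so far in a physicochemical assay for solubility; a lower number here means a less soluble compound, a higher number a more soluble compound
Compound 1 `O=C(c1ccc(C(F)(F)F)cc1)N1CCC(NS(=O)(=O)c2cc(S(=O)(=O)c3ccccc3)ccc2C(F)(F)F)CC1` gives 6300 nM
Compound 2 `O=C(c1ccccn1)N1CCC(NS(=O)(=O)c2cc(S(=O)(=O)c3ccccc3)ccc2C(F)(F)F)CC1` gives 100000 nM
Compound 3 `O=C(O)c1ccc(S(=O)(=O)N2CCC(NS(=O)(=O)c3cc(S(=O)(=O)c4ccccc4)ccc3C(F)(F)F)CC2)cc1` gives 12500 nM

Compound 3 stands within the scatter of compound 1 (a 2.0-fold higher number from compound 1 to compound 3 (0.30 log units; within the scatter)) and clear of compound 2 (an 8.0-fold lower number from compound 2 to compound 3 (0.90 log units; beyond the scatter)). Compound 4 `N#Cc1cccc(S(=O)(=O)N2CCC(NS(=O)(=O)c3cc(S(=O)(=O)c4ccccc4)ccc3C(F)(F)F)CC2)c1` carries 3-cyanophenyl in place of 4-carboxyphenyl on a sulfonyl sulfur. Within the data shown here, no measured step makes this exchange. The nearest evidence is a 2.0-fold higher number from compound 1 to compound 3 (0.30 log units; within the scatter), a step that stays within the scatter. The large step of a 16-fold higher number from compound 1 to compound 2 (1.20 log units; beyond the scatter) brings in pyridin-2-yl, which compound 4 does not carry. Compound 4 shares with compound 1 (6300 nM) the absence of 4-carboxyphenyl, so a slight downward lean is expected in this assay, with no step beyond the scatter. The expected move is a 1.9-fold lower number from compound 3 to compound 4 (0.28 log units; within the scatter). Compound 4 is estimated at 6500 nM, with an expected range from 1800 nM to 22000 nM.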

Compound 4, solubility: 6300 nM
Compound 4: middle estimate off by 1.0-fold (0.01 log units), on the high side; the measured number falls inside the stated range.
By their numbers in this assay, from the lowest: compounds 1, 4 and 3 (each within the scatter of the next); then compound 2.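

The exchange on the sulfonyl sulfur stays within the scatter in this assay (a 2.0-fold lower number from compound 3 to compound 4 (0.30 log units; within the scatter)), so 3-cyanophenyl and 4-carboxyphenyl are not told apart at this position. The (3-cyanophenyl)sulfonyl and (4-(trifluoromethyl)phenyl)carbonyl groups are not told apart either (no change at the digits printed from compound 1 to compound 4 (within the scatter)), while compound 2 stays clear of compound 4 (a 16-fold lower number from compound 2 to compound 4 (1.20 log units; beyond the scatter)). No measurement here gives a reason for these steps.

Still open, on these data alone, is whether the number of compound 2 belongs to pyridin-2-yl alone or needs its carbonyl link. Also open, as far as these compounds go, is whether an amine in place of the nitrile of compound 4 would leave the number within the scatter.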